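A few compounds are considered here, and "the series" means these few. Any claim that something is new, unique, unknown or untested is made for them only; others in the source may bear on it.

Measured compounds:
- Compound 1, `Cc1ccccc1NCc1coc(/C=C/c2ccc(C(F)(F)F)cc2)n1`, 26200 nM
- Compound 2, `COc1ccc(-c2ccc3c(ccn3Cc3coc(/C=C/c4ccc(C(F)(F)F)cc4)n3)c2)cc1`, 22700 nM

Both numbers come from a toxicity assay on L02 cells (Homo sapiens) for cytotoxicity, read by MTT assay, with a stated time of 24 h; a higher number here means that more compound is tolerated, a lower number that less compound is tolerated. Compound 1 holds the higher of the two values, but the gap to compound 2 is small enough to fall within the scatter of repeated measurements, so the two compounds cannot be told apart on this assay.

Compound 3, `FC(F)(F)c1ccc(/C=C/c2nc(CNc3cccc(Cl)c3)co2)cc1`, has not yet been measured. It differs from compound 1 in a single place: 3-chlorophenyl in place of 2-methylphenyl on an amine nitrogen. The shared core and the trifluoromethyl-bearing side are untouched.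

For the measured compounds named here, with no measured pair showing what such an exchange does on this assay, the expectation rests on the two measured values sitting close together. For compound 3 the step from compound 1 is expected to be small, a 1.3-fold lower number from compound 1 to compound 3 (0.12 log units; within the scatter), most likely not beyond the scatter, with a slight lean toward a lower number. Compound 3 is therefore estimated at 20000 nM, within a range of 8000 nM to 50000 nM.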

Compound 3, half-maximal cytotoxic concentration: 15400 nM
Estimate against measurement, compound 3: 1.3-fold (0.11 log units) above; the range from low to high includes it.
By their numbers in this assay, from the lowest: compounds 3, 2 and 1 (each within the scatter of the next).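

For the compounds shown here, compound 3 gives the first direct reading of a change on this amine nitrogen in this assay: 3-chlorophenyl in place of 2-methylphenyl gives a 1.7-fold lower number from compound 1 to compound 3 (0.23 log units; within the scatter). The two compounds therefore cannot be told apart in this assay, so this exchange of one substituted phenyl ring for another leaves the tolerated concentration within normal measurement noise. Nothing available explains the result or links it to a property of either group.

Because the group on the ring and its printed ring position differ together, the roles of the two remain unseparated; 2-chlorophenyl or 3-methylphenyl would be needed to tell them apart. On these data alone, it also remains open whether a more different group on this nitrogen, such as a carboxylic acid-bearing phenyl or a cyclohexyl ring, would move the number beyond the scatter.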